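Hydroxymethyl on the pendant phenyl of a urea series

The source may report more compounds than this note shows. Statements on the series, on what has been measured and on what is new or still open speak of the compounds shown alone.

Measured compounds:
compound 1 `Cc1ccc(C2(CNC(=O)Nc3c(C(C)C)cccc3C(C)C)CCCC2)cc1` gives 25 nM in an assay on microsomes for inhibition of acyl-CoA:cholesterol acyltransferase (Oryctolagus cuniculus); a lower number here means a stronger inhibitor, a higher number a weaker inhibitor
compound 2 `CC(C)c1cccc(C(C)C)c1NC(=O)NCC1(c2cccc(N)c2)CCCC1` gives 21 nM in this assay
compound 3 `CC(C)c1cccc(C(C)C)c1NC(=O)NCC1(c2ccc(N)cc2)CCCC1` gives 29 nM in this assay

Compound 1 stands second highest of the three numbers; its neighbours are compound 3 and compound 2, and both steps from it lie within the scatter: a 1.2-fold lower number from compound 1 to compound 2 (0.08 log units; within the scatter) and a 1.2-fold higher number from compound 1 to compound 3 (0.06 log units; within the scatter). The remaining pair also stays within the scatter: a 1.4-fold higher number from compound 2 to compound 3 (0.14 log units; within the scatter).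

Compound 4 `CC(C)c1cccc(C(C)C)c1NC(=O)NCC1(c2cccc(CO)c2)CCCC1` is not yet measured. It differs from compound 1 at the pendant phenyl on the saturated ring carbon: 3-(hydroxymethyl)phenyl in place of 4-methylphenyl on a saturated ring carbon.

Bearing on this step are the two changes already seen at the same phenyl, a 3-aminophenyl and a 4-aminophenyl in place of the 4-methylphenyl, neither of which moved this assay beyond the scatter. A polar group with one hydrogen-bond donor and one acceptor on that ring is thus tolerated at either position among the compounds seen. For the measured compounds named here, the hydroxymethyl group adds one heavy atom over the amino, and no step directly tests it. The expectation is therefore a step of a 1.1-fold higher number from compound 1 to compound 4 (0.03 log units; within the scatter), none beyond the scatter. Compound 4 is expected to give 27 nM, within 12 nM to 65 nM.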

Compound 4, half-maximal inhibitory concentration: 15 nM
Compound 4: middle estimate off by 1.8-fold (0.26 log units), on the high side; the measured number falls inside the stated range.
By their numbers in this assay, from the lowest: compounds 4, 2, 1 and 3 (each within the scatter of the next).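

The 3-(hydroxymethyl)phenyl group, which brings one hydrogen-bond donor and one acceptor where the 4-methylphenyl has none, extends the range of groups tolerated on the saturated ring carbon in this assay (a 1.7-fold lower number from compound 1 to compound 4 (0.22 log units; within the scatter)). The two amino compounds do not separate from it either: hydroxymethyl in place of amino on an aromatic carbon gives a 1.4-fold lower number from compound 2 to compound 4 (0.15 log units; within the scatter), and the change from the 4-aminophenyl gives a 1.9-fold lower number from compound 3 to compound 4 (0.29 log units; within the scatter), so this position now holds four groups with no step beyond the scatter, and a donor on the pendant phenyl need not be a nitrogen. No measurement shown here offers an explanation for these numbers.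

For the compounds shown here, what the compounds leave open is where tolerance at this phenyl ends, as no step among them goes beyond the scatter, and whether a carboxylic acid or a longer chain such as 2-hydroxyethyl would stay level with compound 4. A 4-(hydroxymethyl)phenyl group would also be needed to test the placement of hydroxymethyl on its own, as the amino pair does for amino.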